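The source may hold more compounds than are shown below. What is called first, only, known or untested is meant among the compounds shown, and "the series" means these compounds.

Measured in a functional assay on G-361 cells (Homo sapiens) for antiproliferative activity, with a stated time of 72 h; on this read-out lower numbers stand for stronger inhibition and higher numbers for weaker inhibition:
- compound 1 `OC[C@H]1O[C@@H](n2cnc3c(NCc4ccc(Br)cc4)ncnc32)[C@H](O)[C@@H]1O`: > 166000 nM
- compound 2 `Cc1ccc(CNc2ncnc3c2ncn3[C@@H]2O[C@H](CO)[C@@H](O)[C@H]2O)cc1`: "not determined" (no result reported)

Compound 2 has no number in this assay, and its entry reads "not determined" (no result reported). It therefore has no place on the scale. Going by the values given here, the only reading is the limit of > 166000 nM in this assay, at which 1 of the 2 values shown sits. That reading belongs to compound 1, and it is a limit, not a number.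

Compound 3 `OC[C@H]1O[C@@H](n2cnc3c(NCc4ccc(OC(F)(F)F)cc4)ncnc32)[C@H](O)[C@@H]1O` keeps the shared core. The change is trifluoromethoxy in place of methyl on an aromatic carbon, para to a large group.

Among the compounds with values here, no measured step sizes such a change, and compound 2 offers no number to step from. In this assay, within the data shown here, no step beyond the scatter is expected, in either direction, from the one reading available. That expectation rests on compound 1 alone, with its limit of > 166000 nM. The assay may well report only a limit again. For compound 3 the estimated value is 90000 nM, with an expected range from 20000 nM to 166000 nM.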

Compound 3, half-maximal inhibitory concentration: > 166000 nM
Compound 3: only a limit was reported; the forecaster's own chance of this, stated with the estimate: 60%; at least 1.8-fold (0.26 log units) between middle value and limit.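

Compound 1 carries bromo where compound 3 carries trifluoromethoxy, and both reach the same limit in this assay, so no new step can be read from them: the limit of > 166000 nM in this assay, at which 2 of the 3 values shown sit.

The compounds shown leave open how far either lies past that limit, and whether this change alters antiproliferative activity at all.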